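The compounds below may be only part of what the source reports. "The series", "measured", "known", "first", "only" and "open" are said of these compounds alone.

Working notes on the aryl variation in this series. Compound 1 `O=C(/C=C/C1=Cc2ccccc2OC1)c1ccc(F)cc1` gives 65.6% in a functional assay on the whole organism for inhibition, with Mus musculus as the target, with a stated time of 1 h, at a dose of 30 mg/kg by the intraperitoneal route; on this read-out lower numbers stand for less inhibition and higher numbers for more inhibition at the one dose given (going by the name of the read-out); compound 2 `O=C(/C=C/C1=Cc2ccccc2OC1)c1cccc(Cl)c1` gives 51%; compound 3 `O=C(/C=C/C1=Cc2ccccc2OC1)c1ccc(Cl)cc1` gives 56.1%. Among the compounds with values here, compound 3 therefore sits within the scatter of both neighbours: a number 9.5 percentage points lower from compound 1 to compound 3 (within the scatter) and a number 5.1 percentage points higher from compound 2 to compound 3 (within the scatter), while a number 14.6 percentage points lower from compound 1 to compound 2 (beyond the scatter) is the only step that exceeds the scatter.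

Compound 4 `O=C(/C=C/C1=Cc2ccccc2OC1)c1ccccc1Br` has not yet been measured. It differs from compound 3 by 2-bromophenyl in place of 4-chlorophenyl on a carbonyl carbon. Within the data shown here, no measured step introduces bromine or a 2-substituted phenyl, so the closest guides are the halogen swap and the shift of chloro around the ring, both of which stayed within the scatter; only the combined move in a number 14.6 percentage points lower from compound 1 to compound 2 (beyond the scatter) went beyond it. A step of modest size at most is expected, with direction uncertain and a slight lean downward given that every change away from compound 1 lowered the number. Compound 4 is estimated at 50%, spanning 35% to 65%, which implies an expected step of a number 6.1 percentage points lower from compound 3 to compound 4 (within the scatter).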

Compound 4, a percentage reported as inhibition, in the whole organism at one dose (the size of the read-out at that dose, not a potency): 56.6%
Estimate against measurement, compound 4: 6.6 percentage points below; measured number inside the range.
By their numbers in this assay, from the lowest: compounds 2, 3, 4 and 1 (each within the scatter of the next, the first and the last beyond it).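

In this assay, 2-bromophenyl on the carbonyl carbon stays within the scatter of each of the other three aryl groups (a number 0.5 percentage points higher from compound 3 to compound 4 (within the scatter); a number 5.6 percentage points higher from compound 2 to compound 4 (within the scatter); a number 9 percentage points lower from compound 1 to compound 4 (within the scatter)). Within the data shown here, the position therefore accepts a bromine-bearing aryl group with no step beyond the scatter, and the only such step in the set remains the one between compound 1 and compound 2, the 3-chlorophenyl change. No measurement at hand accounts for these steps.

Every aryl group shown carries a single halogen, so unsubstituted phenyl and aryl groups bearing an amine, a methoxy group or a carboxylic acid remain open. With one dose and one time point, these numbers also leave open how the compounds would compare across a range of doses.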